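Notes on a fluoro-to-bromo exchange, three measured, one pending

A few compounds are considered here, and "the series" means these few. Any claim that something is new, unique, unknown or untested is made for them only; others in the source may bear on it.

Of the compounds shown here, three have been measured so far: compound 1 `C[C@H](NC(=O)Nc1cccc(F)c1)c1ccccc1`, compound 2 `C[C@@H](NC(=O)Nc1ccc(F)cc1)c1ccccc1` and compound 3 `C[C@H](NC(=O)Nc1cccc(Br)c1)c1ccccc1`. In an ADME assay on the whole organism with Oryza sativa as the target, tested at 1 uM (a lower number here means a stronger effect, a higher number a weaker effect of the compound at the concentration tested), compound 1 gives 94%, compound 2 gives 96% and compound 3 gives 100%. Among the compounds with values here, all three numbers sit close together; the step of a number 6 percentage points higher from compound 1 to compound 3 (within the scatter) is the only one that pairs two compounds differing in a single place, and it lies within the scatter. Compound 2 stands within the scatter of both compound 1 and compound 3, so no order among the three can be read from these numbers.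

The change from compound 1 to compound 3 is bromo in place of fluoro on an aromatic carbon. Compound 2 and compound 1 share the same atoms joined differently; the difference between the two cores is not broken down here.

Compound 4 `C[C@@H](NC(=O)Nc1ccc(Br)cc1)c1ccccc1` has not yet been measured in this assay. It differs from compound 2 by bromo in place of fluoro on an aromatic carbon. This is the same kind of change as from compound 1 to compound 3, not the same change: in the earlier pair the bromo enters meta to a large group, while in compound 4 it enters para to a large group.

Because the step of a number 6 percentage points higher from compound 1 to compound 3 (within the scatter) from compound 1 to compound 3 stayed within the scatter, the step from compound 2 to compound 4 is expected to be of similar size, a number 3 percentage points higher from compound 2 to compound 4 (within the scatter). Within the data shown here, for compound 4 the expected value in this assay is 99%, with a range from 92% to 100%, resting only on compound 2 at 96% and on the single measured step of this kind.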

Compound 4, a percentage reported as activity, at one concentration (the size of the read-out at that concentration, not a potency): 95%
Compound 4: the middle estimate sits 4 percentage points above what was measured; low and high end bracket the measured number.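

In this assay the exchange of fluoro for bromo on an aromatic carbon, here para to a large group, gives a number 1 percentage points lower from compound 2 to compound 4 (within the scatter) on the core of compound 2. Set beside the step on the core of compound 1, the two results do not differ beyond what repeated measurement would allow: the same change on two cores in this assay, a number 6 percentage points higher (within the scatter) from compound 1 to compound 3 and a number 1 percentage points lower (within the scatter) from compound 2 to compound 4, 7 percentage points apart, within the scatter of two such steps
On these two cores, then, the exchange travels without a step beyond the scatter in either case, and nothing here argues for treating fluoro and bromo differently in this assay. This does not show that the exchange is without effect in general, and it does not show that the place on the ring is irrelevant, since two steps within the scatter give no measurable effect to compare and both pairs rest on single readings.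

The compounds shown carry only fluoro or bromo on this ring, so it remains open whether a methoxy group, an amine or a carboxylic acid in the same place would give a step beyond the scatter. Also open, as far as these compounds go, is whether a change elsewhere on the shared core, such as a longer chain in place of the methyl group, would move the read-out away from the narrow band these four compounds occupy.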